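The compounds below may be only part of what the source reports. "The series", "measured", "known", "first", "only" and "open" are said of these compounds alone.

Measured compounds:

Compound 1, `Nc1nn(C(=O)Nc2ccc(Cc3ccccc3)cc2)c2ccccc12`: 10000 nM
Compound 2, `Nc1nn(C(=O)Nc2ccc(Cc3ccccc3)cc2)c2ccc(Cl)cc12`: 4920 nM

Within the data shown here, in a functional assay on UACC-257 cells (Homo sapiens) for antiproliferative activity, read by sulforhodamine B assay, with a stated time of 48 h (on this read-out lower numbers stand for stronger inhibition of growth and higher numbers for weaker inhibition of growth), compound 2 gives 4920 nM, the lowest of the two numbers measured so far. Compound 2 carries chloro where compound 1, which shares the same core, carries hydrogen; in this assay compound 1 gives 10000 nM. Among the measured compounds shown here, the one measured step, a 2.0-fold lower number from compound 1 to compound 2 (0.31 log units; beyond the scatter), shows that putting chloro in place of hydrogen on an aromatic carbon brought a modest gain.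

Compound 3, `Nc1ccc2c(c1)c(N)nn2C(=O)Nc1ccc(Cc2ccccc2)cc1`, has not yet been measured. It differs from compound 2 in one place: amino in place of chloro on an aromatic carbon. For the measured compounds named here, no measured pair shows what amino does at this place; the only comparison at hand concerns chloro against hydrogen. Going by the values given here, since chloro was the one change that gave a gain, removing it and putting amino in its stead is expected to give up some or all of that gain, and a step back toward compound 1 is expected, a 1.6-fold higher number from compound 2 to compound 3 (0.21 log units; within the scatter), though a result close to compound 2 within the scatter cannot be ruled out. For compound 3 the expected value in this assay is 8000 nM, with a range from 3000 nM to 25000 nM.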

Compound 3, concentration for 50% growth inhibition: 14500 nM
For compound 3 the middle estimate is 1.8-fold (0.26 log units) below the measured one, and the stated range covers the measured number.
By their numbers in this assay, from the lowest: compound 2; then compounds 1 and 3 (each within the scatter of the next).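

In this assay, this aromatic carbon has now carried three different groups, and the new result shows that the gain seen with chloro does not extend to every group placed there: amino in place of chloro gives a 2.9-fold higher number from compound 2 to compound 3 (0.47 log units; beyond the scatter). Set against the hydrogen of the unsubstituted core, amino gives a 1.5-fold higher number from compound 1 to compound 3 (0.16 log units; within the scatter), so amino and hydrogen cannot be told apart at this place, and of the three groups only chloro stands apart from the other two. The available data offer no measurement that explains why chloro and amino differ here.

The compounds shown leave open whether the small gain belongs to chloro alone or would also appear with another halogen such as fluoro or bromo, and whether a larger group such as methoxy or a carboxylic acid would match chloro, match hydrogen and amino, or fall outside both. They also leave open whether the order seen at this one place would hold with the same groups on a different aromatic carbon of the shared core.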